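The source may hold more compounds than are shown below. What is called first, only, known or untested is meant among the compounds shown, and "the series" means these compounds.

In an ADME assay on the whole organism (strain CD-1) for metabolic stability, with Mus musculus as the target, at a dose of 3 mg/kg by the intravenous route (a lower number here means that the compound disappears faster, a higher number that the compound lasts longer), compound 1 `CN(Cc1ccccc1OCCCCC(C)(C)C(=O)O)C(=O)c1ccc(-c2ccco2)cc1` gives 4.6 h, compound 2 `C/C(=C\CCCOc1ccccc1CN(C)C(=O)c1ccc(-c2ccco2)cc1)C(=O)O` gives 1.2 h and compound 3 `CC(CCOc1ccccc1CN(C)C(=O)c1ccc(-c2ccco2)cc1)CCC(=O)O` gives 1.7 h. Both a 3.8-fold lower number from compound 1 to compound 2 (0.58 log units; beyond the scatter) and a 2.7-fold lower number from compound 1 to compound 3 (0.43 log units; beyond the scatter) lie beyond the scatter, so compound 3 stands well under compound 1 and level with compound 2. Compound 4 `C/C(=C\COc1ccccc1CN(C)C(=O)c1ccc(-c2ccco2)cc1)CCC(=O)O` brings one new change: 4-carboxy-2-methylbut-1-en-1-yl in place of 4-carboxy-2-methylbutyl on a saturated chain carbon bound to an oxygen on an aromatic ring, that is, 4-carboxy-2-methylbut-1-en-1-yl in place of 4-carboxy-2-methylbutyl. Going by the values given here, no measured step isolates this exact change. The closest evidence is compound 2, which also has a double bond in its chain, and a 1.4-fold higher number from compound 2 to compound 3 (0.15 log units; within the scatter) stays within the scatter. In this assay, the expected step is therefore none beyond the scatter, and it is estimated as a 1.1-fold lower number from compound 3 to compound 4 (0.05 log units; within the scatter). For compound 4, the expected half-life is 1.5 h, with an estimated range of 0.8 h to 2.9 h.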

Compound 4, half-life: 2.3 h
Compound 4: the middle estimate sits 1.5-fold (0.19 log units) below what was measured, within the range that was stated.
By their numbers in this assay, from the lowest: compounds 2, 3, 4 and 1 (each within the scatter of the next, the first and the last beyond it).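

In this assay, adding a double bond to the chain at this position, 4-carboxy-2-methylbut-1-en-1-yl in place of 4-carboxy-2-methylbutyl, gives a 1.4-fold higher number from compound 3 to compound 4 (0.13 log units; within the scatter). Against the chains of the other two compounds the result is a 1.9-fold higher number from compound 2 to compound 4 (0.28 log units; within the scatter) and a 2.0-fold lower number from compound 1 to compound 4 (0.30 log units; within the scatter), so compound 4 cannot be told apart from any of the three, although compound 1 and compound 2 differ beyond the scatter. No measurement shown here accounts for this. Going by these compounds, what a shorter chain at this position, or an amide in place of the carboxylic acid, would do to the half-life stays open.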